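The source may report more compounds than this note shows. Statements on the series, on what has been measured and on what is new or still open speak of the compounds shown alone.

Measured compounds in a functional assay on A375P cells (Homo sapiens) for antiproliferative activity, read by MTT assay, with a stated time of 48 h; a lower number here means a stronger inhibitor, a higher number a weaker inhibitor:
compound 1 `Cc1cc(C(=O)Nc2cccc(-c3ccnc4c(N)cccc34)c2)ccc1Br` gives 9900 nM
compound 2 `Nc1cccc2c(-c3cccc(NC(=O)c4ccc(C(F)(F)F)c(Cl)c4)c3)ccnc12` gives 6100 nM
compound 3 `Nc1cccc2c(-c3cccc(NC(=O)c4ccc(Cl)cc4C(F)(F)F)c3)ccnc12` gives > 20000 nM, a limit of the assay

Compound 1 and compound 2 lie within the usual scatter of each other in this assay, so neither can be set above the other. For compound 3 the assay reports only a limit, (the limit of > 20000 nM in this assay, at which 1 of the 3 values shown sits), and no number. For the measured compounds named here, no step between measured compounds that differ in one place is available, so the move from compound 1 to compound 4 `Cc1cc(C(=O)Nc2cccc(-c3ccnc4c(N)cccc34)c2)c(C)o1` has no measured comparison to lean on. The change is 2,5-dimethylfuran-3-yl in place of 4-bromo-3-methylphenyl on a carbonyl carbon. Compound 4 is expected to show a step of a 1.5-fold higher number from compound 1 to compound 4 (0.18 log units; within the scatter), toward a somewhat higher number, given nothing in the measured set to argue otherwise. Compound 4 is estimated at 15000 nM, between 5000 nM and 40000 nM in this assay.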

Compound 4, half-maximal inhibitory concentration: > 20000 nM
Compound 4: only a limit was reported (the forecaster's own chance of this, stated with the estimate: 35%); middle value at least 1.3-fold (0.12 log units) from the limit.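

In this assay, for the compounds shown here, 2,5-dimethylfuran-3-yl in place of 4-bromo-3-methylphenyl on a carbonyl carbon gives an at least 2.0-fold higher number from compound 1 to compound 4 (0.30 log units; that floor lies within the scatter), the first step that can be read at this position. It shows that this five-membered aromatic ring with 1 hetero atom brings no lower number here. Compound 4 gives only a limit of the assay, so this step is a floor and not a measured size: the limit of > 20000 nM in this assay, at which 2 of the 4 values shown sit.

On these data alone, how far the true value of compound 4 lies past that limit remains open. So does whether an unsubstituted phenyl or a pyridine ring at this position would give a lower number than the 2,5-dimethylfuran-3-yl group.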